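This account rests on a few compounds, and the source may have more. Where it says the series, first, only, none or still open, it means among the compounds named here.

The series shares the core of compound 1 `CCN(CC(=O)NC[C@H]1O[C@H](OC)[C@@H](OS(=O)(=O)O)[C@@H](OS(=O)(=O)O)[C@@H]1OS(=O)(=O)O)C(=O)COS(=O)(=O)O`, which in an assay on isolated protein for binding affinity to vascular endothelial growth factor A, long form (Homo sapiens), read by surface plasmon resonance (on this read-out higher numbers stand for weaker binding and lower numbers for tighter binding), gives 512000 nM. Compound 2 `CO[C@H]1O[C@H](CNC(=O)CN(CCOS(=O)(=O)O)C(C)=O)[C@@H](OS(=O)(=O)O)[C@H](OS(=O)(=O)O)[C@@H]1OS(=O)(=O)O` gives 280000 nM in this assay, and a 1.8-fold lower number from compound 1 to compound 2 (0.26 log units; within the scatter). Compound 3 `CO[C@H]1O[C@H](CNC(=O)CN(C(C)=O)C2CCCCCC2)[C@@H](OS(=O)(=O)O)[C@H](OS(=O)(=O)O)[C@@H]1OS(=O)(=O)O` gives 3000000 nM, the highest of the three numbers; its nearest neighbour is compound 1, with a 5.9-fold higher number from compound 1 to compound 3 (0.77 log units; beyond the scatter), and its furthest is compound 2, with an 11-fold higher number from compound 2 to compound 3 (1.03 log units; beyond the scatter).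

Compound 4 `CO[C@H]1O[C@H](CNC(=O)CN(C(C)=O)C2CCCCC2)[C@@H](OS(=O)(=O)O)[C@H](OS(=O)(=O)O)[C@@H]1OS(=O)(=O)O` differs from compound 3 only in cyclohexyl in place of cycloheptyl on an amide-type nitrogen. For the measured compounds named here, no measured step exchanges one carbocycle for another on that nitrogen: the two steps that end at compound 3 replace a sulfated chain with the cycloheptyl group and are of a different kind, so they set only a rough scale for how much that position can move the read-out. With nothing bearing directly on the present ring change, no step beyond the scatter is expected in either direction, and no change at the digits printed from compound 3 to compound 4 (within the scatter) is the estimated step. Compound 4 is therefore estimated at 3000000 nM in this assay, within 1000000 nM to 9000000 nM.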

Compound 4, dissociation constant: 1700000 nM
The estimate for compound 4 lay 1.8-fold (0.25 log units) above the measured number; measured number inside the range.
By their numbers in this assay, from the lowest: compounds 2 and 1 (each within the scatter of the next); then compounds 4 and 3 (each within the scatter of the next).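

For the compounds shown here, the first exchange of one carbocycle for another on the amide-type nitrogen, cyclohexyl in place of cycloheptyl, stays within the scatter in this assay (a 1.8-fold lower number from compound 3 to compound 4 (0.25 log units; within the scatter)), so this read-out does not separate the two rings. Cyclohexyl also stands apart from the sulfated side chains, as shown by (a 6.1-fold higher number from compound 2 to compound 4 (0.78 log units; beyond the scatter)) and (a 3.3-fold higher number from compound 1 to compound 4 (0.52 log units; beyond the scatter)). Among the four compounds, the two with a carbocycle on that nitrogen therefore give higher numbers than the two bearing a second side-chain sulfooxy group, and none goes against this.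

Still open, going by these compounds, is whether a carboxylic acid or an amine at the end of the ethyl chain of compound 2 would keep its number, and whether a smaller ring such as cyclopentyl would follow cyclohexyl. Nothing available bears on why the number moves at this position.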